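Adding a Chloro Group to Compound 3

The source may hold more compounds than are shown below. What is called first, only, known or untested is meant among the compounds shown, and "the series" means these compounds.

Compound 1 `O=C(CCCCC1CCSS1)NO`: 3.9%
Compound 2 `O=C(CCCCC(S)CCS)Nc1ccc(Cl)cc1`: "not active" (no number reported)
Compound 3 `O=C(CCCCC(CCSC(=O)c1ccccc1)SC(=O)c1ccccc1)Nc1ccccc1`: 0.6%

In a functional assay on NCI-H460 cells (Homo sapiens) for inhibition, read by MTT assay, with a stated time of 24 h, tested at 0.1 ug/mL (on this read-out higher numbers stand for more inhibition of growth at the one concentration tested and lower numbers for less inhibition of growth), compound 3 gives 0.6%. Among the compounds with values here, its only numerical neighbour is compound 1 at 3.9%, and the two values lie within the scatter of each other. Compound 2 has no number and was reported as "not active" (no number reported), so it cannot be placed alongside them. Both numbers are small on this read-out.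

The next compound to be tested is compound 4 `O=C(CCCCC(CCSC(=O)c1ccccc1)SC(=O)c1ccccc1)Nc1cccc(Cl)c1`. It differs from compound 3 by a single change on the aromatic ring: chloro in place of hydrogen on an aromatic carbon. Chloro takes the place of hydrogen on an aromatic carbon, meta to a large group.

Within the data shown here, no measured pair in this small set isolates such a change, so there is no direct precedent for its size. Compound 2 also carries a chloro group on its aromatic ring, but it differs from compound 3 in other ways as well. The expectation is therefore no shift beyond the scatter in this assay, with any movement more likely upward, since compound 3 at 0.6% has little room to fall. The expected change is a number 3.4 percentage points higher from compound 3 to compound 4 (within the scatter). For compound 4 the estimated value is 4%, with an expected range from 0% to 15%.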

Compound 4, percent growth inhibition at one concentration: 15.6%
Estimate against measurement, compound 4: 11.6 percentage points below, outside the stated range (above it).
By their numbers in this assay, from the lowest: compounds 3 and 1 (each within the scatter of the next); then compound 4.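

In this assay, chloro in place of hydrogen on an aromatic carbon, meta to a large group, gives a number 15 percentage points higher from compound 3 to compound 4 (beyond the scatter). Within the data shown here, this is the first step in the set that isolates a single change, and it shows that this place on the ring is not indifferent: phenylcarbamoyl to (3-chlorophenyl)carbamoyl, one added heavy atom with no ring, no charge and no hydrogen-bond donor or acceptor, is enough to move the read-out beyond the scatter. The compounds offer no measurement that would explain the rise.

As far as these compounds go, whether the rise is particular to chloro remains open, since a methoxy group, an amine or a carboxylic acid at the same place could give a step of a different size or direction. Also open, from the compounds shown here alone, are whether chloro on another carbon of this ring would give a similar step and whether the step between these two compounds would hold at other concentrations, given that the read-out rests on one concentration.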